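A few compounds are considered here, and "the series" means these few. Any claim that something is new, unique, unknown or untested is made for them only; others in the source may bear on it.

In a functional assay on SJ-G2 cells (Homo sapiens) for inhibition, read by MTT assay, with a stated time of 72 h (a higher number here means a weaker inhibitor of growth, a lower number a stronger inhibitor of growth), compound 1 `COc1ccc(CNC(=O)/C(C#N)=C/c2ccc3ccccc3c2)cc1` gives 40000 nM. Compound 2 `COc1ccc(CNC(=O)/C(C#N)=C/c2cccc3ccccc23)cc1` is built from the same atoms joined differently; the difference between the two cores is not broken down here. In this assay compound 2 gives 15000 nM, the lowest of the three measured numbers, beyond the scatter from both others. Compound 3 `N#C/C(=C\c1ccc2ccccc2c1)C(=O)NCc1ccc(Cl)c(Cl)c1` carries 3,4-dichlorophenyl in place of 4-methoxyphenyl on a saturated chain carbon bound to an amide-type nitrogen; in this assay compound 3 gives 49000 nM, and the step of a 1.2-fold higher number from compound 1 to compound 3 (0.09 log units; within the scatter) lies within the scatter. Compound 4 `N#C/C(=C\c1cccc2ccccc12)C(=O)NCc1ccc(Cl)c(Cl)c1` arises from compound 2 by the same change, (3,4-dichlorophenyl in place of 4-methoxyphenyl on a saturated chain carbon bound to an amide-type nitrogen), at a place described in identical words. For compound 4 the expected step is a 1.2-fold higher number from compound 2 to compound 4 (0.08 log units; within the scatter), since the same change gave only a 1.2-fold higher number from compound 1 to compound 3 (0.09 log units; within the scatter). Compound 4 is therefore estimated at 18000 nM in this assay, expected between 8000 nM and 40000 nM.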

Compound 4, concentration for 50% growth inhibition: 13000 nM
For compound 4 the middle estimate is 1.4-fold (0.14 log units) above the measured one; low and high end bracket the measured number.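

In this assay, putting 3,4-dichlorophenyl in place of 4-methoxyphenyl gives a 1.2-fold lower number from compound 2 to compound 4 (0.06 log units; within the scatter), so on this core too the change stays within the scatter. The steps on the two cores agree: the same change on two cores in this assay, a 1.2-fold higher number (0.09 log units; within the scatter) from compound 1 to compound 3 and a 1.2-fold lower number (0.06 log units; within the scatter) from compound 2 to compound 4, 1.4-fold (0.15 log units) apart, within the scatter of two such steps. On these two cores, then, the change carries over as a step too small to tell from repeat scatter, but two pairs set no rule for other cores, and they do not show that the two groups behave alike in any other test.

The compounds shown leave open whether an amine, a carboxylic acid or a longer chain in place of these groups, on the saturated chain carbon bound to the amide-type nitrogen, would move the number beyond the scatter.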